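Phenyl to 2-iodophenyl on the shared core

This account rests on a few compounds, and the source may have more. Where it says the series, first, only, none or still open, it means among the compounds named here.

In a functional assay on PC-3 cells (Homo sapiens) for antiproliferative activity, read by MTT assay, with a stated time of 48 h (a lower number here means a stronger inhibitor, a higher number a weaker inhibitor), compound 2 `Cc1cccn2cc(-c3nnc(-c4ccccc4)o3)nc12` gives 22800 nM. Compound 1 `c1ccc(-c2nnc(-c3cn4ccccc4n3)o2)cc1` gives 22200 nM, and compound 3 `Cc1cccn2cc(-c3nnc(-c4ccc(N(C)C)cc4)o3)nc12` gives 11600 nM. Both lie within the scatter of compound 2, so compound 2 is not separated from either of them.

Compound 4 `Cc1cccn2cc(-c3nnc(-c4ccccc4I)o3)nc12` differs from compound 2 by iodo in place of hydrogen on an aromatic carbon, ortho to a large group (iodo in place of hydrogen on an aromatic carbon). Going by the values given here, no measured compound carries iodo, so the evidence is indirect. Methyl in place of hydrogen on an aromatic carbon gave a 1.0-fold higher number from compound 1 to compound 2 (0.01 log units; within the scatter). Adding a dimethylamino group gave a 2.0-fold lower number from compound 2 to compound 3 (0.29 log units; within the scatter). Neither of these two single changes moved the number beyond the scatter.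

On that basis, no step beyond the scatter is expected in this assay, and the estimated step is a 1.3-fold lower number from compound 2 to compound 4 (0.10 log units; within the scatter). For compound 4 the estimated value is 18000 nM, with an expected range from 7000 nM to 40000 nM.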

Compound 4, half-maximal inhibitory concentration: 33500 nM
For compound 4 the middle estimate is 1.9-fold (0.27 log units) below the measured one; the measured number falls inside the stated range.
By their numbers in this assay, from the lowest: compounds 3, 1, 2 and 4 (each within the scatter of the next, the first and the last beyond it).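

In this assay, phenyl to 2-iodophenyl comes with a 1.5-fold higher number from compound 2 to compound 4 (0.17 log units; within the scatter), so a single iodo group on this aromatic carbon, ortho to a large group, does not carry the number beyond the scatter. Compound 4 is the only compound shown with iodo and the only direct reading at this place, and its step joins the two earlier ones in staying within the scatter, so none of the single changes shown separates two compounds in this assay. Nothing measured here gives a reason for this small step.

The compounds shown leave open whether a carboxylic acid or a primary amine at this place would give a step beyond the scatter. They also leave open whether iodo would read the same on the core of compound 1.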